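The source may report more compounds than this note shows. Statements on the series, on what has been measured and on what is new or still open speak of the compounds shown alone.

Measured compounds:
- compound 1 `Cc1cc(C)cc(-c2cnc(-c3cccnc3)c(C(=O)N(C)Cc3ccc4nccnc4c3)c2)c1`: 78.5 nM
- compound 2 `COc1ccc(CNC(=O)c2cc(-c3cc(C)cc(C)c3)cnc2-c2cccnc2)cc1`: 22 nM

Among the measured compounds shown here, in an assay on isolated protein for displacement of a labelled ligand from Orexin receptor type 2 (Homo sapiens), read by scintillation counting, with a stated time of 60 min (a higher number here means a weaker inhibitor, a lower number a stronger inhibitor), compound 2 gives the lowest of the two numbers so far. Its nearest neighbour is compound 1, which in this assay gives 78.5 nM, a gap beyond the usual scatter. Compound 3 `Cc1cc(C)cc(-c2cnc(-c3cccnc3)c(C(=O)NCc3ccc(F)c(C)c3)c2)c1` has not been measured. It differs from compound 2 by 4-fluoro-3-methylphenyl in place of 4-methoxyphenyl on a saturated chain carbon bound to an amide-type nitrogen. For the measured compounds named here, no step between measured compounds covers this change, so nothing here says which way it goes. The expectation is a step from compound 2 to compound 3 of a 1.4-fold higher number from compound 2 to compound 3 (0.13 log units; within the scatter), not beyond the scatter. Compound 3 is estimated at 30 nM, with a range from 8 nM to 110 nM.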

Compound 3, inhibition constant: 18 nM
The estimate for compound 3 lay 1.7-fold (0.22 log units) above the measured number; measured number inside the range.
By their numbers in this assay, from the lowest: compounds 3 and 2 (each within the scatter of the next); then compound 1.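

Exchanging 4-methoxyphenyl for 4-fluoro-3-methylphenyl on a saturated chain carbon bound to an amide-type nitrogen gives a 1.2-fold lower number from compound 2 to compound 3 (0.09 log units; within the scatter) in this assay and leaves the two compounds within the scatter. In this pair, the hydrogen-bond acceptor counted in 4-methoxyphenyl is therefore not needed to keep the number at this level. Nothing measured here accounts for this result.

On these data alone, whether an amine, a carboxylic acid or a longer chain is tolerated at this position remains open. Among the compounds shown here, compound 1 differs from compound 2 in more than one place, so no step to it can be read.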